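The source may report more compounds than this note shows. Statements on the series, on what has been measured and on what is new or still open speak of the compounds shown alone.

Of the compounds shown here, three sharing one core have been measured in an assay on CHO-K1 cells for antagonist activity at transient receptor potential cation channel subfamily V member 1 (Homo sapiens), read by FLIPR and calcium flux, with a stated time of 6 min; on this read-out higher numbers stand for weaker inhibition and lower numbers for stronger inhibition. Compound 1 `Cn1ncc2c(NC(=O)NCc3cc(C(F)(F)F)nn3-c3cccc(Cl)c3)cccc21` gives 2.3 nM. Compound 2 `CC(=O)n1ncc2c(NC(=O)NCc3cc(C(F)(F)F)nn3-c3cccc(Cl)c3)cccc21` is its acetyl counterpart; compound 2 gives 17.4 nM, and compound 3 `CC(C)(C)c1cc(CNC(=O)Nc2cccc3[nH]ncc23)n(-c2cccc(Cl)c2)n1` gives 0.6 nM. Compound 2 thus stands highest of the three numbers. For the measured compounds named here, the only single-point change measured is a 7.6-fold higher number from compound 1 to compound 2 (0.88 log units; beyond the scatter), acetyl in place of methyl on an aromatic nitrogen. Compound 4 `CC(=O)n1ncc2c(NC(=O)NCc3cc(C(C)(C)C)nn3-c3cccc(Cl)c3)cccc21` differs from compound 2 by tert-butyl in place of trifluoromethyl on an aromatic carbon. Going by the values given here, no measured step covers this exact change. Compound 3 carries the same tert-butyl group, but it also lacks both the acetyl and the methyl on the aromatic nitrogen, so it differs from compound 1 in two places; its number is lower than that of compound 1, though the two changes cannot be separated on the data shown. A modest lowering is therefore expected for compound 4, a 2.2-fold lower number from compound 2 to compound 4 (0.34 log units; beyond the scatter). Compound 4 is estimated to give 8 nM in this assay, with a range from 2.5 nM to 25 nM.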

Compound 4, inhibition constant: 29.5 nM
The estimate for compound 4 lay 3.7-fold (0.57 log units) below the measured number; measured number outside the range, above it.
By their numbers in this assay, from the lowest: compound 3; then compound 1; then compounds 2 and 4 (each within the scatter of the next).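

In this assay, tert-butyl in place of trifluoromethyl on this aromatic carbon gives a 1.7-fold higher number from compound 2 to compound 4 (0.23 log units; within the scatter), so with the acetyl on the aromatic nitrogen, the two groups cannot be told apart at this position. With tert-butyl held constant, acetyl in place of hydrogen on the aromatic nitrogen gives a 49-fold higher number from compound 3 to compound 4 (1.69 log units; beyond the scatter), so among these compounds the large step belongs to the nitrogen substituent and not to the swap at this carbon. Nothing shown explains either step.

On these data alone, whether the two groups also match when the aromatic nitrogen carries methyl or hydrogen stays open, since compound 1 and compound 3 differ in two places. Also open, as far as these compounds go, is how a smaller or differently built group, such as a nitrile, an amine or a carboxylic acid, would fare on this carbon.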